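The source may report more compounds than this note shows. Statements on the series, on what has been measured and on what is new or still open speak of the compounds shown alone.

In a functional assay on A549 cells (Homo sapiens) for antiproliferative activity, read by MTT assay, with a stated time of 72 h (on this read-out lower numbers stand for stronger inhibition and higher numbers for weaker inhibition), compound 1, `O=C(Nc1ccccc1F)C(Cl)Cl`, gives 87500 nM. Compound 2, `O=C(Nc1cccc(F)c1)C(Cl)Cl`, was tested in this assay, and for compound 2 the result reads "not determined" (no result reported), so it stands without a number of its own. Compound 3, `COc1cccc(NC(=O)C(Cl)Cl)c1`, has not yet been measured in this assay. Its change from compound 2 is methoxy in place of fluoro on an aromatic carbon. For the measured compounds named here, with no measured pair of this kind to draw on, the step from compound 2 to compound 3 in this assay is expected to be small, without a clear direction, and likely within the usual scatter. Compound 3 is therefore estimated at 80000 nM in this assay, with a range from 20000 nM to 320000 nM.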

Compound 3, half-maximal inhibitory concentration: 25800 nM
The estimate for compound 3 lay 3.1-fold (0.49 log units) above the measured number; the range from low to high includes it.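

In this assay, for the compounds shown here, compound 2 has no number, so no step to compound 3 can be read. The compounds shown leave open how methoxy in place of fluoro shifts activity. No further evidence bears on this result.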